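Swapping the aryl group on the piperazine nitrogen

This account rests on a few compounds, and the source may have more. Where it says the series, first, only, none or still open, it means among the compounds named here.

The measured compounds and their values in a functional assay on HL-60 cells (Homo sapiens) for inhibition, read by MTT assay, with a stated time of 72 h (a lower number here means a stronger inhibitor, a higher number a weaker inhibitor), are:
compound 1, `Cc1nc(-c2ccccc2)c(C(=O)N2CCN(c3ccc(Cl)c(Cl)c3)CC2)o1`, 124 nM;
compound 2, `Cc1nc(-c2ccccc2)c(C(=O)N2CCN(c3cccc(Cl)c3Cl)CC2)o1`, 133 nM;
compound 3, `C=C(C)c1ccc(N2CCN(C(=O)c3oc(C)nc3-c3ccccc3)CC2)cc1`, "not active" (no number reported).

Compounds 1 and 2 share a core and differ only in the dichlorophenyl group on the ring nitrogen; the step of a 1.1-fold higher number from compound 1 to compound 2 (0.03 log units; within the scatter) shows that moving the two chlorine atoms makes no difference beyond the scatter. Compound 3 carries a 4-(1-methylethenyl)phenyl group in the same place and was reported as not active, so no single number stands for it; it cannot be placed on the same scale as compounds 1 and 2, other than lying weaker than both.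

Compound 4, `Cc1nc(-c2ccccc2)c(C(=O)N2CCN(c3cccc(F)c3)CC2)o1`, is not yet measured. It differs from compound 3 in one place: 3-fluorophenyl in place of 4-(1-methylethenyl)phenyl on an amine nitrogen in a ring. Among the measured compounds shown here, no measured step touches the 4-(1-methylethenyl)phenyl group or a fluorophenyl group, so the only guidance is indirect. Compounds 1 and 2 show that a halogen-bearing phenyl group at this position gives a measurable inhibitor, and the step of a 1.1-fold higher number from compound 1 to compound 2 (0.03 log units; within the scatter) shows that the arrangement of those halogens hardly matters. A single fluorine is a smaller change than two chlorines, so the outcome is uncertain. Compound 4 is expected to fall between compound 3 and compounds 1 and 2, estimated at 500 nM with a range from 100 nM to 8000 nM.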

Compound 4, half-maximal inhibitory concentration: 45 nM
Estimate against measurement, compound 4: 11-fold (1.05 log units) above; measured number below the stated range.
By their numbers in this assay, from the lowest: compound 4; then compounds 1 and 2 (each within the scatter of the next).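

In this assay, the aryl group on the amine nitrogen in the ring can move the number beyond the scatter, which the swap between the two dichlorophenyl groups did not show: 3-fluorophenyl gives a 3.0-fold lower number from compound 2 to compound 4 (0.47 log units; beyond the scatter) and a 2.8-fold lower number from compound 1 to compound 4 (0.44 log units; beyond the scatter). Compound 3 was reported as not active, while compound 4 has the lowest number of the set, so at this one place the change from 4-(1-methylethenyl)phenyl to 3-fluorophenyl separates a compound with no reported number from the strongest of these inhibitors. Nothing on hand gives a measured reason for either difference.

The compounds shown leave open whether the lower number belongs to the fluorine itself or simply to having one halogen rather than two, a question that an unsubstituted phenyl, a 3-chlorophenyl or a 4-fluorophenyl group at the same place would help to answer. They also leave open whether the same order would hold if the rest of the shared core were changed, since all four compounds keep it unchanged.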